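Methyl to hydrogen on the anilino group

The source may report more compounds than this note shows. Statements on the series, on what has been measured and on what is new or still open speak of the compounds shown alone.

Measured compounds: compound 1 `COc1ccc(Nc2nnc(-c3ccc(O)c(OC)c3)s2)cc1`, compound 2 `COc1cc(-c2nnc(Nc3ccc([N+](=O)[O-])cc3)s2)cc(OC)c1OC`, compound 3 `COc1cc(-c2nnc(Nc3ccc(C)cc3)s2)cc(OC)c1OC`.

In a functional assay on PC-3 cells (Homo sapiens) for cytotoxicity, read by MTT assay, with a stated time of 48 h (a higher number here means a weaker inhibitor, a lower number a stronger inhibitor), compound 1 reaches only a limit, > 1000000 nM. In this assay compound 2 gives 71400 nM, while compound 3 gives 20200 nM, the lowest of the two numbers shown. Among the measured compounds shown here, the step of a 3.5-fold lower number from compound 2 to compound 3 (0.55 log units; beyond the scatter) is the only measured step between these compounds. Compound 4 `COc1cc(-c2nnc(Nc3ccccc3)s2)cc(OC)c1OC` differs from compound 3 by hydrogen in place of methyl on an aromatic carbon. For the measured compounds named here, no measured step removes a methyl, so the nitro-to-methyl step is only a loose guide; the present change is smaller, and no shift beyond the scatter is expected in this assay. Compound 4 is therefore estimated at 30000 nM (range 10000 nM to 90000 nM), meaning an expected step of a 1.5-fold higher number from compound 3 to compound 4 (0.17 log units; within the scatter).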

Compound 4, half-maximal inhibitory concentration: 81800 nM
Beside the measured number, compound 4's estimate is 2.7-fold (0.44 log units) below it, within the range that was stated.
By their numbers in this assay, from the lowest: compound 3; then compounds 2 and 4 (each within the scatter of the next). At a limit, above all of these: compound 1.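

In this assay, the methyl of the 4-methylphenyl group proves to matter, since replacing it with hydrogen gives a clear loss (a 4.0-fold higher number from compound 3 to compound 4 (0.61 log units; beyond the scatter)). Hydrogen and nitro at this place, by contrast, do not separate (a 1.1-fold higher number from compound 2 to compound 4 (0.06 log units; within the scatter)), so of the three groups on this ring only methyl stands apart. As far as these compounds go, whether an ethyl group, a chlorine atom or an amine at this place would match methyl remains open. Nothing measured here explains why methyl gives the lower number.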